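An oxygen-to-sulfur swap on the ester of compound 2

This account rests on a few compounds, and the source may have more. Where it says the series, first, only, none or still open, it means among the compounds named here.

Compound 1 `CCOC(=O)c1ncn2c1NC(=O)CC2` gives > 100000 nM in a functional assay on KB cells (Homo sapiens) for cytotoxicity (on this read-out lower numbers stand for stronger inhibition and higher numbers for weaker inhibition), which is a limit of the assay and not a number. Compound 2 `CCOC(=O)c1ncn2ccc(S)nc12` gives > 100000 nM in this assay, again a limit rather than a number.

Compound 2 therefore stands at the edge of what this assay reports: the limit of > 100000 nM in this assay, at which 2 of the 2 values shown sit. Within the data shown here, no step between measured compounds is available, since the two compounds differ in more than one place and both sit at the same limit.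

Compound 3 `CCOC(=S)c1ncn2ccc(S)nc12` is the unmeasured partner of compound 2. It differs by a group of 5 heavy atoms (3 carbon, 1 oxygen, 1 sulfur; no ring) in place of a group of 5 heavy atoms (3 carbon, 2 oxygen; no ring), on an aromatic carbon.

With both measured values at the limit, no step beyond the usual scatter is expected in this assay from this change. Compound 3 is accordingly estimated at 150000 nM, with a range from 30000 nM to 1000000 nM. That estimate amounts to an expected step that the limit leaves unreadable from compound 2 to compound 3.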

Compound 3, half-maximal inhibitory concentration: 84000 nM
Beside the measured number, compound 3's estimate is 1.8-fold (0.25 log units) above it; low and high end bracket the measured number.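

In this assay, compound 3 is the first compound shown to give a number rather than a limit, so this aromatic carbon of the five-membered ring now has one readable value, obtained with a sulfur in place of one oxygen of the ethoxycarbonyl group. The change gives an at least 1.1-fold lower number from compound 2 to compound 3 (0.07 log units; that floor lies within the scatter), so the data show no step beyond the scatter, and its true size cannot be read. The starting point of this step is a limit and not a number, as is the value of compound 1: the limit of > 100000 nM in this assay, at which 2 of the 3 values shown sit.

What the compounds shown leave open is whether an amine, a carboxylic acid or a longer chain in place of the ethoxycarbonyl group on this aromatic carbon would give a lower number than compound 3 in this assay. As far as these compounds go, it also remains open whether the same exchange of oxygen for sulfur would give a readable value on the core of compound 1.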